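Benzoyl in Place of Benzyl: Reaching for a Number

The compounds below may be only part of what the source reports. "The series", "measured", "known", "first", "only" and "open" are said of these compounds alone.

Measured so far:
- compound 1, `Cc1nnc(CN2CCCC2)n1-c1ccc(Cl)cc1Cc1ccccc1`: > 100 mg/kg
- compound 2, `Cc1nnc(CN)n1-c1ccc(Cl)cc1C(O)c1ccccc1`: 9 mg/kg

From the compounds shown here alone, in a functional assay on the whole organism (strain CF-1) with Mus musculus as the target (a lower number here means that less compound is needed, a higher number that more compound is needed for the effect), compound 1 gives only a limit, > 100 mg/kg, so its true value is unknown (the limit of > 100 mg/kg in this assay, at which 1 of the 2 values shown sits). Compound 2 gives 9 mg/kg in this assay. Within the data shown here, no single-change step links these two compounds, so their values are simply what they are.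

Compound 3, `Cc1nnc(CN2CCCC2)n1-c1ccc(Cl)cc1C(=O)c1ccccc1`, differs from compound 1 by benzoyl in place of benzyl on an aromatic carbon. Among the measured compounds shown here, no measured step guides this change, so an improvement is expected, tentatively, of size an at least 2.5-fold lower number from compound 1 to compound 3 (0.39 log units; beyond the scatter) toward a lower dose. Compound 3 is therefore estimated at 40 mg/kg, with a range from 10 mg/kg to 150 mg/kg.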

Compound 3, dose for half-maximal effect: 4 mg/kg
Beside the measured number, compound 3's estimate is 10-fold (1.00 log units) above it; measured number outside the range, below it.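

In this assay, putting benzoyl in place of benzyl on this aromatic carbon, ortho to a large group, gives an at least 25-fold lower number from compound 1 to compound 3 (1.39 log units; beyond the scatter). This single change therefore turns a compound that reaches no measurable dose in this test into one with a real number. Compound 1 gives only a limit, so the true size of the step stays unknown: the limit of > 100 mg/kg in this assay, at which 1 of the 3 values shown sits.

Still open, from the compounds shown here alone, is whether the carbonyl or the whole benzoyl group carries this gain. An acetyl group or a phenylsulfonyl group in the same place would help to separate the two.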